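A few compounds are considered here, and "the series" means these few. Any claim that something is new, unique, unknown or untested is made for them only; others in the source may bear on it.

Working notes on the series. Of the compounds shown here, three have been measured in a functional assay on CWR22R cells (Homo sapiens) for antiproliferative activity, read by propidium iodide staining, with a stated time of 96 h; on this read-out higher numbers stand for weaker inhibition and lower numbers for stronger inhibition. Compound 1 (`CC(O)(CSc1cccc(S(F)(F)(F)(F)F)c1)C(=O)Nc1ccc(C#N)c(C(F)(F)F)c1`) gives 20400 nM, compound 2 (`CC(O)(CSc1ccc(S(F)(F)(F)(F)F)cc1)C(=O)Nc1ccc([N+](=O)[O-])cc1C(F)(F)F`) gives 13100 nM and compound 3 (`CC(O)(CSc1cccc(S(F)(F)(F)(F)F)c1)C(=O)Nc1ccc(S(F)(F)(F)(F)F)cc1`) gives 17700 nM. Compound 3 therefore lies within the usual scatter of both other compounds, and the numbers do not separate it from either.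

The next compound is compound 4 (`CC(O)(CSc1cccc(C(F)(F)F)c1)C(=O)Nc1ccc(S(F)(F)(F)(F)F)cc1`), which departs from compound 3 in one place: a group of 4 heavy atoms (1 carbon, 3 fluorine; no ring) in place of a group of 6 heavy atoms (5 fluorine, 1 sulfur; no ring), on an aromatic carbon. Trifluoromethyl enters on an aromatic carbon of a six-membered aromatic ring of carbon only, meta to a large group.

Going by the values given here, no measured pair differs in one place only, so the data hold no direct precedent for this exchange. Among the compounds with values here, the only guide is the narrow spread of the three values, and these compounds differ from one another in more than one place. With compound 3 at 17700 nM as the reference, no change beyond the scatter is expected in this assay, and no direction is favoured. The expected step is a 1.0-fold lower number from compound 3 to compound 4 (0.02 log units; within the scatter), which is effectively no change. The estimated value for compound 4 is 17000 nM, with an expected range of 8000 nM to 36000 nM.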

Compound 4, half-maximal inhibitory concentration: 23400 nM
For compound 4 the middle estimate is 1.4-fold (0.14 log units) below the measured one; the measured number falls inside the stated range.
By their numbers in this assay, from the lowest: compounds 2, 3, 1 and 4 (each within the scatter of the next).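

In this assay, going by these compounds alone, trifluoromethyl in place of the group of 6 heavy atoms (5 fluorine, 1 sulfur), on an aromatic carbon meta to a large group, gives a 1.3-fold higher number from compound 3 to compound 4 (0.12 log units; within the scatter) and provides the first step that isolates a single place. At this position the read-out does not tell the two groups apart, so going from 6 heavy atoms to 4 shows no change that can be separated from the scatter. Nothing available bears on why the two groups read alike.

The compounds shown leave open whether this position accepts groups of another kind, such as an amine or a carboxylic acid; the two groups seen here both count 0 hydrogen-bond donors and 0 hydrogen-bond acceptors. They also leave open whether trifluoromethyl would read the same at the second place where compound 3 and compound 4 both carry the group of 6 heavy atoms, and whether any exchange at either place can move the number beyond the scatter.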